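This account rests on a few compounds, and the source may have more. Where it says the series, first, only, none or still open, it means among the compounds named here.

Measured compounds:

Compound 1, `COc1ccc(NC(=O)c2cccc(/C=C3\CC(=O)N(c4ccccc4)C3=O)c2)cc1`, in an ADME assay on SW480 cells (Homo sapiens) for cytotoxicity, read by MTT assay, with a stated time of 72 h; on this read-out higher numbers stand for weaker inhibition and lower numbers for stronger inhibition: compound 1 gives > 100000 nM, which is a limit of the assay.
Compound 2, `Cc1ccc(NC(=O)c2cccc(/C=C3\CC(=O)N(c4ccccc4)C3=O)c2)cc1`: in this assay compound 2 gives > 100000 nM, also a limit.
Compound 3, `O=C(Nc1ccc(Cl)cc1)c1cccc(/C=C2\CC(=O)N(Cc3ccccc3)C2=O)c1`: in this assay compound 3 gives > 100000 nM, again a limit.

All three measured compounds therefore sit at the same limit, which is recorded in the limit of > 100000 nM in this assay, at which 3 of the 3 values shown sit. For the measured compounds named here, no compound has a number that could be placed above or below another, and compound 3 stands exactly where compounds 1 and 2 stand. Going by the values given here, the only change among the measured compounds that can be read as a single step, a step that the two limits leave unreadable from compound 1 to compound 2, is itself unreadable, because both of its ends are limits.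

Compound 4, `O=C(Nc1ccc(Cl)cc1)c1cccc(/C=C2\CC(=O)N(c3ccccc3)C2=O)c1`, is the unmeasured compound. It differs from compound 3 in one place: phenyl in place of benzyl on an amide-type nitrogen in a ring. Compounds 1 and 2 already carry a phenyl on that same amide-type nitrogen in the ring, and both reach only the limit, so the phenyl group at this place has so far not brought a readable number in this assay. Among the compounds with values here, no measured step therefore points to a change beyond the scatter, and compound 4 is expected to stay with the others at the limit. The step from compound 3 to compound 4 is estimated as a step that the limit leaves unreadable from compound 3 to compound 4, that is, no step beyond the scatter. Compound 4 is estimated at 150000 nM, with a range from 60000 nM to 500000 nM.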

Compound 4, half-maximal inhibitory concentration: > 100000 nM
Compound 4: only a limit was reported; the forecaster's own chance of this, stated with the estimate: 85%; the middle value does not contradict the limit.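

The steps from compound 1, compound 2 and compound 3 to compound 4 cannot be read, as all four compounds sit at one limit: the limit of > 100000 nM in this assay, at which 4 of the 4 values shown sit.

The compounds shown leave open whether any change to the shared core would give a readable number in this assay and so how the phenyl, benzyl, chloro, methyl and methoxy groups compare there.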